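Alkyl chain and halogen variation in the series

The source may hold more compounds than are shown below. What is called first, only, known or untested is meant among the compounds shown, and "the series" means these compounds.

Compound 1 `CCCCC1(O)C(=O)Nc2ccc(Nc3ccc(F)cc3)cc21` gives 6500 nM in a functional assay on A549 cells (Homo sapiens) for antiproliferative activity, read by MTT assay, with a stated time of 48 h; on this read-out lower numbers stand for stronger inhibition and higher numbers for weaker inhibition. Compound 2 `CC(C)CCC1(O)C(=O)Nc2ccc(Nc3ccc(F)cc3)cc21` carries methyl in place of hydrogen on a saturated chain carbon bound to two saturated chain carbons and gives 5700 nM in this assay, a step of a 1.1-fold lower number from compound 1 to compound 2 (0.06 log units; within the scatter). Compound 3 `CCCCC1(O)C(=O)Nc2ccc(Nc3ccc(Cl)cc3)cc21` gives 2800 nM in this assay; its core differs from that of compound 1 by chloro in place of fluoro on an aromatic carbon, a step of a 2.3-fold lower number from compound 1 to compound 3 (0.37 log units; beyond the scatter). Compound 4 `CCCCCC1(O)C(=O)Nc2ccc(Nc3ccc(Cl)cc3)cc21` is not yet measured and differs from compound 3 by methyl in place of hydrogen on a saturated chain carbon, four bonds along the chain from a saturated ring carbon. This is the same kind of change as that between compound 1 and compound 2, but not the same: there the methyl enters on a saturated chain carbon bound to two saturated chain carbons, here on a saturated chain carbon four bonds along the chain from a saturated ring carbon. Because a 1.1-fold lower number from compound 1 to compound 2 (0.06 log units; within the scatter) lies within the scatter, a similarly small step is expected here, a 1.1-fold lower number from compound 3 to compound 4 (0.03 log units; within the scatter). Compound 4 is therefore expected to give about 2600 nM in this assay, estimated between 1300 nM and 5500 nM.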

Compound 4, half-maximal inhibitory concentration: 1900 nM
Estimate against measurement, compound 4: 1.4-fold (0.14 log units) above; low and high end bracket the measured number.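

In this assay the added methyl gives a 1.5-fold lower number from compound 3 to compound 4 (0.17 log units; within the scatter), and this step does not differ from the earlier one on the core of compound 1: the same change on two cores in this assay, a 1.1-fold lower number (0.06 log units; within the scatter) from compound 1 to compound 2 and a 1.5-fold lower number (0.17 log units; within the scatter) from compound 3 to compound 4, 1.3-fold (0.11 log units) apart, within the scatter of two such steps. On these two cores, one carrying fluoro and one carrying chloro, the methyl change stays within the scatter. This does not show that the change carries over to other cores, and the comparison does not separate place from core, since the methyl enters on a saturated chain carbon bound to two saturated chain carbons on one core and on a saturated chain carbon four bonds along the chain from a saturated ring carbon on the other.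

Going by these compounds, a longer chain on either core remains open. So does a bromo or a methoxy group in place of the halogen.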